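Three Values at the Limit and a Fourth to Come

A few compounds are considered here, and "the series" means these few. Any claim that something is new, unique, unknown or untested is made for them only; others in the source may bear on it.

Compound 1 `Cn1cc(C2=C(c3n[nH]c4ncccc34)C(=O)NC2=O)c2ccccc21`, compound 2 `Cn1cc(C2=C(c3nn(CCCn4cccc4)c4ncccc34)C(=O)N(c3ccccc3)C2=O)c2ccccc21` and compound 3 `Cn1cc(C2=C(c3nn(CCCN4CCCCC4)c4ncccc34)C(=O)N(c3ccc(Cl)cc3)C2=O)c2ccccc21` share one core and were tested in a functional assay on SMMC-7721 cells (Homo sapiens) for antiproliferative activity, read by MTT assay, with a stated time of 48 h; a lower number here means a stronger inhibitor, a higher number a weaker inhibitor. In this assay compound 1 gives > 100000 nM, which is a limit of the assay rather than a number. In this assay compound 2 gives > 100000 nM, again only a limit. In this assay compound 3 gives > 100000 nM, also a limit. Compound 2 therefore stands where every value shown stands: the limit of > 100000 nM in this assay, at which 3 of the 3 values shown sit. Compound 4 `Cn1cc(C2=C(c3nn(CCCCn4ccnc4)c4ncccc34)C(=O)N(c3ccccc3)C2=O)c2ccccc21` is not yet measured; it differs from compound 2 by one change ((1H-imidazol-1-yl)methyl in place of 1H-pyrrol-1-yl on a saturated chain carbon, three bonds along the chain from an aromatic nitrogen). For the measured compounds named here, with no measured step to lean on, the expected step of a number no higher from compound 2 to compound 4 (the limit leaves the size open) is essentially none beyond the scatter. Compound 4 is estimated in this assay at 100000 nM, within a range from 30000 nM to 300000 nM.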

Compound 4, half-maximal inhibitory concentration: 1760 nM
Compound 4: middle estimate off by 57-fold (1.75 log units), on the high side; measured number outside the range, below it.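

Putting 4-(1H-imidazol-1-yl)butyl in place of 3-(1H-pyrrol-1-yl)propyl gives an at least 56-fold lower number from compound 2 to compound 4 (1.75 log units; beyond the scatter) in this assay and so shows that one change at this place can move the result far. For the compounds shown here, compound 2 itself offers a limit and not a number, so the true size of the step stays unknown, and the earlier compounds showed no such movement: the limit of > 100000 nM in this assay, at which 3 of the 4 values shown sit.

The change adds both chain length and a second ring nitrogen, and the compounds shown do not separate the two. A 3-(1H-imidazol-1-yl)propyl group or a 4-(1H-pyrrol-1-yl)butyl group would be needed to tell them apart.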